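A few compounds are considered here, and "the series" means these few. Any claim that something is new, unique, unknown or untested is made for them only; others in the source may bear on it.

Working notes on the series. Compound 1 `CCCc1ccc(NC2=CC(=O)c3nc4n(c3C2=O)[C@H]2OC[C@@H](O)[C@H]2OC4)cc1` and compound 2 `COc1ccc(NC2=CC(=O)c3c(nc4n3[C@H]3OC[C@@H](O)[C@H]3OC4)C2=O)cc1` share one core and differ only in the aryl group on the amine nitrogen. In a functional assay on MCF7 cells (Homo sapiens) for inhibition, read by sulforhodamine B assay (a higher number here means a weaker inhibitor, a lower number a stronger inhibitor), compound 1 gives 4660 nM, and compound 2 gives 4470 nM; the two numbers lie within the scatter of each other, so no separation between them is shown.

Compound 3 `Cc1ccc(NC2=CC(=O)c3nc4n(c3C2=O)[C@H]2OC[C@@H](O)[C@H]2OC4)cc1C` is not yet measured. It differs from compound 1 in one place: 3,4-dimethylphenyl in place of 4-propylphenyl on an amine nitrogen. Among the compounds with values here, no step between measured compounds carries this change, so the expectation rests on compound 1 alone and on the observation that compound 2 gives 4470 nM with a different aryl group and yet lands in the same range.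

Compound 3 is therefore expected to give 4500 nM in this assay, with a range from 1500 nM to 13000 nM. The step of a 1.0-fold lower number from compound 1 to compound 3 (0.02 log units; within the scatter) is expected to stay within the scatter, with no direction beyond it.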

Compound 3, half-maximal inhibitory concentration: 2080 nM
For compound 3 the middle estimate is 2.2-fold (0.34 log units) above the measured one, within the range that was stated.
By their numbers in this assay, from the lowest: compound 3; then compounds 2 and 1 (each within the scatter of the next).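

In this assay, the aryl group on the amine nitrogen can shift the number beyond the scatter, which compound 1 and compound 2 did not show: there is a 2.2-fold lower number from compound 1 to compound 3 (0.35 log units; beyond the scatter), a modest step, with 3,4-dimethylphenyl in place of 4-propylphenyl. This single step cannot tell whether the loss of the propyl chain or the presence of two methyl groups carries the difference. Nothing on hand bears on why the number moves.

Open, from the compounds shown here alone, is how an unsubstituted phenyl, a phenyl with a single methyl, or a phenyl with a longer chain such as butyl would read on this nitrogen. Also open, going by these compounds, is whether a phenyl carrying an amine or a carboxylic acid would keep the number of compound 3 or lose it.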